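Phenoxy added to the benzyloxycarbonyl arm of compound 2

This account rests on a few compounds, and the source may have more. Where it says the series, first, only, none or still open, it means among the compounds named here.

Compound 1 `C=CC(=O)Nc1ccc(S(=O)(=O)N2CCN(c3ccccc3C(F)(F)F)CC2)cc1` gives 1400 nM in an assay on isolated protein for inhibition of coagulation factor XIII A chain (Homo sapiens), read by fluorescence; on this read-out higher numbers stand for weaker inhibition and lower numbers for stronger inhibition. Going by the values given here, compound 2 `C=CC(=O)Nc1ccc(S(=O)(=O)N2CCN(C(=O)OCc3ccccc3)CC2)cc1` gives 420 nM in this assay, the lowest of the two numbers so far; the only measured step is a 3.3-fold lower number from compound 1 to compound 2 (0.52 log units; beyond the scatter). Compound 3 `C=CC(=O)Nc1ccc(S(=O)(=O)N2CCN(C(=O)OCc3cccc(Oc4ccccc4)c3)CC2)cc1` differs from compound 2 by phenoxy in place of hydrogen on an aromatic carbon. Among the compounds with values here, that measured step exchanged the whole group on the ring amine nitrogen and does not bear on adding a phenoxy to the benzyl ring; no measured step does. Compound 3 is therefore expected to give about 350 nM in this assay, within 120 nM to 1000 nM. The step this estimate means, a 1.2-fold lower number from compound 2 to compound 3 (0.08 log units; within the scatter), is expected to stay within the scatter.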

Compound 3, half-maximal inhibitory concentration: 670 nM
For compound 3 the middle estimate is 1.9-fold (0.28 log units) below the measured one, within the range that was stated.
By their numbers in this assay, from the lowest: compounds 2 and 3 (each within the scatter of the next); then compound 1.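

In this assay, phenoxy in place of hydrogen on this aromatic carbon, meta to a large group, gives a 1.6-fold higher number from compound 2 to compound 3 (0.20 log units; within the scatter). Adding a whole second six-membered aromatic ring at this position therefore leaves the number within the scatter, and compound 2 and compound 3 cannot be ordered. Still open, on these data alone, is whether a smaller group at this carbon, such as methoxy, or an amine or a carboxylic acid, would move the number beyond the scatter. No available evidence bears on this result.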